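Methyl on the ring nitrogen of compound 1: what to expect

This account rests on a few compounds, and the source may have more. Where it says the series, first, only, none or still open, it means among the compounds named here.

Measured so far in a functional assay on BT-549 cells (Homo sapiens) for cytotoxicity, read by MTT assay, with a stated time of 48 h; a higher number here means a weaker inhibitor, a lower number a stronger inhibitor:
compound 1 `O=C1CNc2nc(Nc3ccccc3)ncc2N1`, > 100000 nM, a limit of the assay
compound 2 `O=C1CNc2nc(Nc3ccc(F)cc3)ncc2N1`, 92400 nM
compound 3 `O=C1CNc2nc(Nc3ccc(Cl)cc3)ncc2N1`, 17700 nM

Compound 1 thus stands only at a limit in this assay, so its own number is not known. Compound 4 `CN1CC(=O)Nc2cnc(Nc3ccccc3)nc21` differs from it by methyl in place of hydrogen on a nitrogen on an aromatic ring in a ring. The measured steps all concern an aromatic carbon instead: an at least 1.0-fold lower number from compound 1 to compound 2 (0.03 log units; that floor lies within the scatter), an at least 5.6-fold lower number from compound 1 to compound 3 (0.75 log units; beyond the scatter) and a 5.2-fold lower number from compound 2 to compound 3 (0.72 log units; beyond the scatter). None of them touches a ring nitrogen, so they offer no guide to this change, and no step beyond the scatter is expected in this assay. Compound 4 is therefore expected near 100000 nM, within 30000 nM to 300000 nM. That amounts to an expected step of a number no higher from compound 1 to compound 4 (the limit leaves the size open), most likely reported again only as a limit.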

Compound 4, half-maximal inhibitory concentration: > 100000 nM
Compound 4 ended at the assay's limit; the forecaster's own chance of this, stated with the estimate: 60%; the middle value sits exactly at the limit.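

Within the data shown here, compound 1 and compound 4 both stand only at a limit, so no step between them can be read: the limit of > 100000 nM in this assay, at which 2 of the 4 values shown sit. Going by these compounds, whether methyl in place of hydrogen on that ring nitrogen changes the strength of the shared core stays open.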